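Working notes: compound 3 against compounds 1 and 2

This account rests on a few compounds, and the source may have more. Where it says the series, first, only, none or still open, it means among the compounds named here.

Compound 1 `NNC(=O)COc1ccncc1-c1ccc2ccccc2c1` carries an (aminocarbamoyl)methoxy group on the shared core. In a functional assay on HCT-116 cells (Homo sapiens) for inhibition, read by MTT assay, with a stated time of 72 h (a higher number here means a weaker inhibitor of growth, a lower number a stronger inhibitor of growth), compound 1 gives "not determined" (no result reported), so it has no number of its own to stand on. Compound 2 `O=C(/C=C/c1ccncc1-c1ccc2cc[nH]c2c1)N1CCOCC1` is a related member with a different side chain. In this assay compound 2 reaches only > 30000 nM, which is a limit of the assay and not a number. The one result in hand is therefore (the limit of > 30000 nM in this assay, at which 1 of the 2 values shown sits), and it places the series at the weak edge of what the assay can read.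

Compound 3 `CN(C)C(=O)/C=C/c1ccncc1-c1ccc2ccccc2c1` is the next member to be tested. Against compound 1 the change is 2-(dimethylcarbamoyl)ethenyl in place of (aminocarbamoyl)methoxy on an aromatic carbon. Within the data shown here, no step between two measured compounds exists in this set, so no measured size of change can be quoted. For this assay the expected step has no certain direction and is unlikely to carry the compound far from a weak reading, an expectation held because the limit of > 30000 nM in this assay, at which 1 of the 2 values shown sits, is all the series has shown so far. Compound 3 is expected to give 20000 nM in this assay, with a range from 4000 nM to 100000 nM.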

Compound 3, concentration for 50% growth inhibition: 4540 nM
For compound 3 the middle estimate is 4.4-fold (0.64 log units) above the measured one, and the stated range covers the measured number.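

No new step can be read: in this assay compound 1 gives "not determined" (no result reported), and the exchange of (aminocarbamoyl)methoxy for 2-(dimethylcarbamoyl)ethenyl leading to compound 3 therefore has no measured size. The compounds shown leave open how far any single change on the shared core moves growth inhibition in this assay.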